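Moving the Fluorine Around the Benzyl Ring

A few compounds are considered here, and "the series" means these few. Any claim that something is new, unique, unknown or untested is made for them only; others in the source may bear on it.

Compound 1 `COc1ccc(-c2c(CO)n(Cc3ccccc3)c3ccc(OC(F)(F)F)cc23)cn1` carries a plain benzyl group on the aromatic nitrogen of the shared core. In an assay for antagonist activity at proteinase-activated receptor 4 (Homo sapiens) (on this read-out lower numbers stand for stronger inhibition and higher numbers for weaker inhibition), compound 1 is reported only as a limit, > 10000 nM. Compound 2 `COc1ccc(-c2c(CO)n(Cc3ccccc3F)c3ccc(OC(F)(F)F)cc23)cn1` places a fluorine on an aromatic carbon of that benzyl group. In this assay compound 2 is likewise reported only as a limit, > 10000 nM. The step that the two limits leave unreadable from compound 1 to compound 2 therefore has no readable size, since both values rest at the limit of > 10000 nM in this assay, at which 2 of the 2 values shown sit. Compound 3 `COc1ccc(-c2c(CO)n(Cc3cccc(F)c3)c3ccc(OC(F)(F)F)cc23)cn1`, still unmeasured, differs from compound 2 by 3-fluorophenyl in place of 2-fluorophenyl on a saturated chain carbon bound to an aromatic nitrogen. Among the measured compounds shown here, the single measured step offers no readable size and no direction, so nothing beyond the usual scatter is expected in this assay, and a further limit is the most likely outcome. The expected step is a step that the limit leaves unreadable from compound 2 to compound 3, essentially no change. The estimate for compound 3 in this assay is 15000 nM, between 4000 nM and 60000 nM.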

Compound 3, half-maximal inhibitory concentration: > 10000 nM
Compound 3: only a limit was reported (the forecaster's own chance of this, stated with the estimate: 85%); the middle value lies beyond the limit too.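

Among the compounds shown here, no step between compound 1, compound 2 and compound 3 can be read in this assay because all three values are limits: the limit of > 10000 nM in this assay, at which 3 of the 3 values shown sit.

Going by these compounds, whether fluorine on the benzyl group affects inhibition at all, and whether 2-fluorobenzyl and 3-fluorobenzyl differ, remains open.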